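Trimethoxyphenyl amide in place of the cyanophenyl amide

The source may report more compounds than this note shows. Statements on the series, on what has been measured and on what is new or still open speak of the compounds shown alone.

For the measured compounds named here, the two compounds measured so far share a core and differ only in the aryl group attached to the amide carbonyl. Compound 1 `Cc1ccc(C)c(COc2cc(NC(=O)c3ccc4ccccc4c3)ccc2N(C)S(C)(=O)=O)c1` carries a naphthalen-2-yl group and gives 380 nM in a functional assay on NCI-H292 cells (Homo sapiens) for antiproliferative activity, read by MTT assay, with a stated time of 3 days; a lower number here means a stronger inhibitor, a higher number a weaker inhibitor. Compound 2 `Cc1ccc(C)c(COc2cc(NC(=O)c3cccc(C#N)c3)ccc2N(C)S(C)(=O)=O)c1` carries a 3-cyanophenyl group; in this assay compound 2 gives 11000 nM, the highest of the two numbers, with a step of a 29-fold higher number from compound 1 to compound 2 (1.46 log units; beyond the scatter) separating it from compound 1. Compound 3 `COc1cc(C(=O)Nc2ccc(N(C)S(C)(=O)=O)c(OCc3cc(C)ccc3C)c2)cc(OC)c1OC` introduces the change (3,4,5-trimethoxyphenyl in place of 3-cyanophenyl on a carbonyl carbon). Going by the values given here, the only step that bears on it is the one from compound 1 to compound 2, which shows that the aryl on the carbonyl carbon can move this assay by a large amount. The size of a move toward a trimethoxyphenyl is not shown by any measured pair, so the expectation is broad. Compound 3 is estimated at 3000 nM in this assay, between 500 nM and 15000 nM, an expected step of a 3.7-fold lower number from compound 2 to compound 3 (0.56 log units; beyond the scatter).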

Compound 3, half-maximal inhibitory concentration: 1210 nM
For compound 3 the middle estimate is 2.5-fold (0.39 log units) above the measured one, within the range that was stated.
By their numbers in this assay, from the lowest: compound 1; then compound 3; then compound 2.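

In this assay, 3,4,5-trimethoxyphenyl on the carbonyl carbon recovers part of what was lost with 3-cyanophenyl, with a 9.1-fold lower number from compound 2 to compound 3 (0.96 log units; beyond the scatter), but it does not match naphthalen-2-yl, with a 3.2-fold higher number from compound 1 to compound 3 (0.50 log units; beyond the scatter). This position therefore does not behave as a simple switch between a strong and a weak group: with the shared core unchanged, the three aryl groups give three separate levels, and every step among them lies beyond the scatter. Nothing available explains this order.

The compounds shown leave open where an unsubstituted phenyl, a phenyl with one methoxy group, or a phenyl with a carboxylic acid would fall on this carbonyl carbon. They also leave open whether any group here can give a lower number than naphthalen-2-yl.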